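The source may report more compounds than this note shows. Statements on the series, on what has been measured and on what is new or still open speak of the compounds shown alone.

Working notes on the series.

Three compounds have numbers in a toxicity assay on HEK-293T cells (Homo sapiens) for cytotoxicity, read by MTT assay, with a stated time of 72 h; a lower number here means a stronger inhibitor, a higher number a weaker inhibitor. Compound 1 `CC1(C)OCC(Cn2cc(Cn3c4c(c5ccccc53)C(=O)c3c[n+]([O-])c5ccccc5c3C4=O)nn2)O1` gives 5510 nM. Compound 2 `O=C1c2c[n+]([O-])c3ccccc3c2C(=O)c2c1c1ccccc1n2Cc1cn([C@@H]2C[C@H](O)[C@@H](CO)O2)nn1` gives 820 nM. Compound 3 `CC1(C)OC[C@@H](Cn2cc(Cn3c4c(c5ccccc53)C(=O)c3c[n+]([O-])c5ccccc5c3C4=O)nn2)O1` gives 6020 nM, the highest of the three; compound 1 is nearest, a 1.1-fold higher number from compound 1 to compound 3 (0.04 log units; within the scatter), a gap within the scatter and attributable to the fact that one of compounds 1 and 3 is drawn with a defined configuration and the other without, at the place where they differ; compound 2 is furthest, a 7.3-fold higher number from compound 2 to compound 3 (0.87 log units; beyond the scatter).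

Going by the values given here, the only step beyond the scatter is the exchange of the (2,2-dimethyl-1,3-dioxolan-4-yl)methyl group for the 4-hydroxy-5-(hydroxymethyl)oxolan-2-yl group on the aromatic nitrogen: a 6.7-fold lower number from compound 1 to compound 2 (0.83 log units; beyond the scatter), and the same exchange read the other way, a 7.3-fold higher number from compound 2 to compound 3 (0.87 log units; beyond the scatter).

Compound 4 `O=C1c2c[n+]([O-])c3ccccc3c2C(=O)c2c1c1ccccc1n2Cc1cn([C@@H]2O[C@H](CO)[C@@H](O)[C@H](O)[C@H]2O)nn1` is not yet measured. It differs from compound 3 by 3,4,5-trihydroxy-6-(hydroxymethyl)oxan-2-yl in place of (2,2-dimethyl-1,3-dioxolan-4-yl)methyl on an aromatic nitrogen. Among the compounds with values here, the change resembles the one from compound 3 to compound 2 in kind, a hydroxylated ring in place of the acetal-protected one, though the ring entering here is six-membered and carries more hydroxyl groups. Only the two sugar-type steps bear on this; both were modest and pointed to a lower number when the hydroxylated ring was present. A step of similar size and direction is therefore expected, a 5.0-fold lower number from compound 3 to compound 4 (0.70 log units; beyond the scatter), with wider uncertainty since the entering group is not identical to that of compound 2. For compound 4 the expected value in this assay is 1200 nM, within the range 400 nM to 4000 nM.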

Compound 4, half-maximal inhibitory concentration: 940 nM
For compound 4 the middle estimate is 1.3-fold (0.11 log units) above the measured one; the range from low to high includes it.
By their numbers in this assay, from the lowest: compounds 2 and 4 (each within the scatter of the next); then compounds 1 and 3 (each within the scatter of the next).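

In this assay, going by these compounds alone, the 3,4,5-trihydroxy-6-(hydroxymethyl)oxan-2-yl group in place of the (2,2-dimethyl-1,3-dioxolan-4-yl)methyl group on the aromatic nitrogen gives a 6.4-fold lower number from compound 3 to compound 4 (0.81 log units; beyond the scatter) and a 5.9-fold lower number from compound 1 to compound 4 (0.77 log units; beyond the scatter), and compounds 1 and 3 can stand side by side as starting points for this exchange, their own gap lying within the scatter and attributed to one thing: the fact that one of compounds 1 and 3 is drawn with a defined configuration and the other without, at the place where they differ A second hydroxylated ring therefore now shows a step beyond the scatter in the same direction as the one seen with compound 2, so this exchange no longer rests on a single entering group. Between the two hydroxylated rings there is a 1.1-fold higher number from compound 2 to compound 4 (0.06 log units; within the scatter), so in this assay the six-membered ring and the five-membered one are not told apart at this position.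

The compounds shown change the ring and its hydroxyl groups together, which leaves open whether the ring or the hydroxyl groups go with the step. From the compounds shown here alone, an open-chain diol, an amine or a carboxylic acid on the same aromatic nitrogen would help separate the two, and how each would read in this assay remains open.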